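Hydroxy for fluoro on the aryl ring: working notes

The source may hold more compounds than are shown below. What is called first, only, known or untested is meant among the compounds shown, and "the series" means these compounds.

- compound 1 `Oc1ccc(-c2nnc(SCCCN3CCN(c4nc5ccccc5o4)CC3)o2)cc1` gives 117000 nM in a functional assay on A-431 cells (Homo sapiens) for inhibition, read by MTT assay, with a stated time of 72 h; on this read-out lower numbers stand for stronger inhibition and higher numbers for weaker inhibition
- compound 2 `Fc1ccc(-c2nnc(SCCCN3CCN(c4nc5ccccc5s4)CC3)o2)cc1` gives 67000 nM in this assay

Among the compounds with values here, compound 2 lies within the usual scatter of compound 1, the only other measured compound, so the two numbers cannot be ranked against each other.

The next entry is compound 3 `Oc1ccc(-c2nnc(SCCCN3CCN(c4nc5ccccc5s4)CC3)o2)cc1` which has hydroxy in place of fluoro on an aromatic carbon, para to a large group, so that 4-fluorophenyl becomes 4-hydroxyphenyl (hydroxy in place of fluoro on an aromatic carbon). Within the data shown here, no measured pair isolates this change, and the data offer no direct step for it. Among the measured compounds shown here, the only indirect evidence is that compound 1 carries hydroxy and gives 117000 nM while compound 2 carries fluoro and gives 67000 nM in this assay with no gap beyond the scatter. A step beyond the scatter in either direction is therefore not expected. The expected change is a 1.2-fold higher number from compound 2 to compound 3 (0.08 log units; within the scatter) as an estimate. For compound 3 the estimated value is 80000 nM with an expected range of 35000 nM to 180000 nM in this assay pending measurement.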

Compound 3, half-maximal inhibitory concentration: 54700 nM
The estimate for compound 3 lay 1.5-fold (0.17 log units) above the measured number; low and high end bracket the measured number.
By their numbers in this assay, from the lowest: compounds 3, 2 and 1 (each within the scatter of the next, the first and the last beyond it).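

Hydroxy in place of fluoro on an aromatic carbon, para to a large group, now has a matched pair, with 1,3-benzothiazol-2-yl held constant on the amine nitrogen in a ring: a 1.2-fold lower number from compound 2 to compound 3 (0.09 log units; within the scatter) in this assay, so 4-fluorophenyl and 4-hydroxyphenyl cannot be ranked against each other here. The series also gains its first readable single-place step, with 4-hydroxyphenyl held constant: 1,3-benzothiazol-2-yl in place of 1,3-benzoxazol-2-yl on that nitrogen gives a 2.1-fold lower number from compound 1 to compound 3 (0.33 log units; beyond the scatter), a modest step that lies at a different position from the hydroxy and fluoro exchange. No measurement on these compounds bears on why either step has the size it has.

From the compounds shown here alone, whether a methoxy, an amine or a carboxylic acid at the same aromatic carbon would move the number beyond the scatter remains open. Also open, going by these compounds, is whether the step from 1,3-benzoxazol-2-yl to 1,3-benzothiazol-2-yl would hold with 4-fluorophenyl in place of 4-hydroxyphenyl, and what a longer chain between the shared core and the amine nitrogen would do.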